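Cyclopropylamino in place of pyrrolidin-1-yl on a carbonyl carbon

The source may hold more compounds than are shown below. What is called first, only, known or untested is meant among the compounds shown, and "the series" means these compounds.

Compound 1 `NS(=O)(=O)c1ccc(-c2cc(C(=O)C3CC3)nn2-c2ccc(Cl)cc2)cc1`: 25600 nM
Compound 2 `NS(=O)(=O)c1ccc(-c2cc(C(=O)C3CCC3)nn2-c2ccc(Cl)cc2)cc1`: 17200 nM
Compound 3 `NS(=O)(=O)c1ccc(-c2cc(C(=O)N3CCCC3)nn2-c2ccc(Cl)cc2)cc1`: 57900 nM

In a physicochemical assay for solubility, read by HPLC, in phosphate buffer, measured as kinetic solubility, at pH 7.4 (a higher number here means a more soluble compound, a lower number a less soluble compound), compound 3 gives 57900 nM as the highest of the three numbers. Compound 4 `NS(=O)(=O)c1ccc(-c2cc(C(=O)NC3CC3)nn2-c2ccc(Cl)cc2)cc1` has not yet been measured. It carries cyclopropylamino in place of pyrrolidin-1-yl on a carbonyl carbon. For the measured compounds named here, no measured compound carries cyclopropylamino, so the evidence is indirect. The closest measured steps are the two that bring in pyrrolidin-1-yl (a 2.3-fold higher number from compound 1 to compound 3 (0.35 log units; beyond the scatter); a 3.4-fold higher number from compound 2 to compound 3 (0.53 log units; beyond the scatter)), and both are modest. With that group leaving, a modest step to a lower number is expected (a 2.3-fold lower number from compound 3 to compound 4 (0.36 log units; beyond the scatter)). Compound 4 is estimated at 25000 nM with an expected range from 9000 nM to 60000 nM (this assay).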

Compound 4, solubility: 72600 nM
For compound 4 the middle estimate is 2.9-fold (0.46 log units) below the measured one; measured number above the stated range.
By their numbers in this assay, from the lowest: compounds 2 and 1 (each within the scatter of the next); then compounds 3 and 4 (each within the scatter of the next).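

In this assay cyclopropylamino on this carbonyl carbon cannot be told apart from pyrrolidin-1-yl (a 1.3-fold higher number from compound 3 to compound 4 (0.10 log units; within the scatter)), even though it brings in a hydrogen-bond donor and a smaller ring. Both steps from the groups joined through carbon now point the same way (a 4.2-fold higher number from compound 2 to compound 4 (0.63 log units; beyond the scatter); a 2.8-fold higher number from compound 1 to compound 4 (0.45 log units; beyond the scatter)), so across these four compounds the two groups joined through nitrogen stand above the two joined through carbon, and none goes against this.

As far as these compounds go, whether morpholine or an open-chain amine at this carbon would join compound 3 and compound 4 stays open. No measurement shown here accounts for the split between the two pairs.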